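Swapping the aryl amide for an acid chain

The compounds below may be only part of what the source reports. "The series", "measured", "known", "first", "only" and "open" are said of these compounds alone.

Working notes on the series. Among the measured compounds shown here, in a functional assay on NCI-H1975 cells (Homo sapiens) for antiproliferative activity, read by MTT assay, with a stated time of 72 h (a higher number here means a weaker inhibitor, a lower number a stronger inhibitor), compound 1 (`O=C(Nc1cc(Nc2ccc(Cl)cc2)ncn1)c1ccc(F)cc1`) gives 17600 nM, the only true number available so far. Compound 2 (`CCOC(=O)CCCC(=O)Nc1cc(Nc2cccc(Cl)c2)ncn1`) reads > 30000 nM, which is a limit of the assay and not a number. Compound 1 therefore cannot be ranked firmly, and it stands as the sole numerical reference point.

Compound 3 (`O=C(O)CCC(=O)Nc1cc(Nc2ccc(Cl)cc2)ncn1`) is the next compound to follow. Its change from compound 1 is 2-carboxyethyl in place of 4-fluorophenyl on a carbonyl carbon. The 2-carboxyethyl sits in place of 4-fluorophenyl on a carbonyl carbon, so the ring on that side is gone.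

For the measured compounds named here, no measured step between compounds exists to size this change. The expectation is thus a loose one, and the limit reading of compound 2 at > 30000 nM tilts it toward weak inhibition. In this assay the expected step is a 1.7-fold higher number from compound 1 to compound 3 (0.23 log units; within the scatter), toward weaker inhibition but not clearly beyond the usual scatter of repeats. A limit reading is also quite possible. For compound 3 the estimated value is 30000 nM, with an expected range from 14000 nM to 60000 nM.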

Compound 3, half-maximal inhibitory concentration: 2730 nM
The estimate for compound 3 lay 11-fold (1.04 log units) above the measured number; measured number outside the range, below it.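

Among the compounds shown here, the step at this place is the first that can be sized. In this assay, 2-carboxyethyl in place of 4-fluorophenyl on a carbonyl carbon gives a 6.4-fold lower number from compound 1 to compound 3 (0.81 log units; beyond the scatter), so at this place the six-membered aromatic ring of compound 1 is not needed for activity, and an open chain with no ring gives the stronger inhibitor of the pair. For the compounds shown here, compound 2 reads > 30000 nM, which is a limit of the assay and not a number; it also differs from compound 3 in more than one place, so no step involving it can be read. No measurement shown here accounts for the size or direction of the step from the aromatic ring to the acid chain.

The compounds shown leave open which part of 2-carboxyethyl carries this gain, since the free carboxylic acid is not set against its methyl ester, a primary amide or a plain alkyl chain on the same core. On these data alone, it also remains open whether a longer or shorter acid chain, or a saturated ring such as cyclohexyl, would read the same at this place.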